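From phenylsulfonyl to dimethylcarbamoyl on the amine nitrogen

The source may hold more compounds than are shown below. What is called first, only, known or untested is meant among the compounds shown, and "the series" means these compounds.

Compound 2 `CCCCc1ccc(CNS(=O)(=O)c2ccccc2)c(=O)n1Cc1ccc(-c2ccccc2-c2nn[nH]n2)cc1` holds the lowest of the two numbers in a functional assay (aorta) for antagonist activity, with Oryctolagus cuniculus as the target (a higher number here means a weaker inhibitor, a lower number a stronger inhibitor), giving 7 nM; compound 1 `CCCCc1ccc(CNC(=O)NC2CCCCC2)c(=O)n1Cc1ccc(-c2ccccc2-c2nn[nH]n2)cc1` gives 90 nM. Compound 3 `CCCCc1ccc(CNC(=O)N(C)C)c(=O)n1Cc1ccc(-c2ccccc2-c2nn[nH]n2)cc1` differs from compound 2 in one place: dimethylcarbamoyl in place of phenylsulfonyl on an amine nitrogen. Within the data shown here, the only measured step that bears on it, a 13-fold lower number from compound 1 to compound 2 (1.11 log units; beyond the scatter), ran the other way, replacing a carbamoyl group on that nitrogen with phenylsulfonyl. Putting a carbamoyl group back is therefore expected to raise the number again, though dimethylcarbamoyl is not cyclohexylcarbamoyl, so a somewhat smaller step is expected. Compound 3 is estimated at 60 nM, within 20 nM to 200 nM, an expected step of an 8.6-fold higher number from compound 2 to compound 3 (0.93 log units; beyond the scatter).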

Compound 3, half-maximal inhibitory concentration: 2 nM
For compound 3 the middle estimate is 30-fold (1.48 log units) above the measured one; measured number below the stated range.
By their numbers in this assay, from the lowest: compound 3; then compound 2; then compound 1.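

In this assay, a carbamoyl group on the amine nitrogen proves no drawback in itself: dimethylcarbamoyl gives a 3.5-fold lower number from compound 2 to compound 3 (0.54 log units; beyond the scatter) and so shows that phenylsulfonyl is not needed for a low number here. The group on the carbonyl carbon matters greatly, as dimethylamino in place of cyclohexylamino gives a 45-fold lower number from compound 1 to compound 3 (1.65 log units; beyond the scatter) within the same urea series. Nothing available explains either step. The compounds shown leave open whether diethylamino or pyrrolidine on that carbonyl carbon would keep the low number, and how a plain acetyl group on the amine nitrogen would compare.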